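The compounds below may be only part of what the source reports. "The series", "measured", "known", "first", "only" and "open" are said of these compounds alone.

Three compounds share one core and differ in the group carried on an aromatic carbon. Compound 1 `Cc1cc2c(c(N)nn2C)c(N2CCCCC2)n1` carries piperidin-1-yl there, and in an assay on isolated protein for inhibition of RAC-beta serine/threonine-protein kinase (Homo sapiens), read by mobility shift assay, tested at 30 uM (a higher number here means more inhibition at the concentration tested (going by the name of the read-out), a lower number less inhibition), compound 1 gives 0%. Compound 2 `Cc1cc2c(c(N)nn2C)c(N2CC[C@H](O)C2)n1` carries 3-hydroxypyrrolidin-1-yl, and in this assay compound 2 gives 4%. Compound 3 `COCCNc1nc(C)cc2c1c(N)nn2C` carries (2-methoxyethyl)amino, and in this assay compound 3 gives -3%. Compound 3 has the lowest of the three numbers, yet the steps of a number 3 percentage points lower from compound 1 to compound 3 (within the scatter) and a number 7 percentage points lower from compound 2 to compound 3 (within the scatter) lie within the scatter, as does a number 4 percentage points higher from compound 1 to compound 2 (within the scatter), so the three compounds are not separated by the read-out. Compound 4 `COCCNc1nc(-c2ccccc2)cc2c1c(N)nn2C` differs from compound 3 in a different place: phenyl in place of methyl on an aromatic carbon. None of the three measured steps touches this position; each of them changes the amine group, and none moved the read-out beyond the scatter. Among the compounds with values here, no measured step therefore bears directly on the change from compound 3 to compound 4, and the flat picture across the measured compounds is all there is to go on. The step expected is a number 8 percentage points higher from compound 3 to compound 4 (within the scatter), that is, none beyond the scatter. Compound 4 is expected to give 5% in this assay, with a range from -10% to 25%.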

Compound 4, a percentage reported as inhibition, at one concentration (the size of the read-out at that concentration, not a potency): -1%
Estimate against measurement, compound 4: 6 percentage points above, within the range that was stated.
By their numbers in this assay, from the lowest: compounds 3, 4, 1 and 2 (each within the scatter of the next).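

Phenyl in place of methyl, on the aromatic carbon next to the ring nitrogen, is the first change shown at this position, and in this assay the step is a number 2 percentage points higher from compound 3 to compound 4 (within the scatter). The flat picture therefore reaches beyond the amine group: a six-membered aromatic ring of carbon only at this second place leaves the read-out no more separated than the amine changes did, and no listed step in the series lies beyond the scatter. No measurement at hand offers an explanation for this result.

Going by these compounds, whether an amine or a carboxylic acid at this position would separate from methyl and phenyl remains open. Also open, on these data alone, is whether phenyl would give the same flat result alongside piperidin-1-yl or 3-hydroxypyrrolidin-1-yl on the shared core.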